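The compounds below may be only part of what the source reports. "The series", "measured", "known", "first", "only" and "open" are said of these compounds alone.

Measured so far in an assay on HEK293 cells for displacement of a labelled ligand from Type-2 angiotensin II receptor (Homo sapiens); a lower number here means a stronger inhibitor, a higher number a weaker inhibitor:

compound 1, `CC[C@H](C)[C@H](NC(=O)c1cccc(Cn2ccnc2)c1)C(=O)NNS(=O)(=O)c1c(C)cc(C)cc1C`: 8500 nM
compound 2, `CC[C@H](C)[C@H](NC(=O)c1cccc(Cn2ccnc2)c1)C(=O)Nc1nccs1`: 42000 nM

Compound 1 holds the lower of the two numbers in this assay. Compound 2 gives a higher number, and the gap between them lies beyond the usual scatter, so on these two values compound 1 is the stronger inhibitor of the pair. Among the measured compounds shown here, no single-point step between measured compounds is known, so the effect of changing the group on the sulfonyl sulfur has not yet been seen.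

Compound 3, `CC[C@H](C)[C@H](NC(=O)c1cccc(Cn2ccnc2)c1)C(=O)NNS(=O)(=O)c1ccc(OC)cc1`, differs from compound 1 in one place: 4-methoxyphenyl in place of 2,4,6-trimethylphenyl on a sulfonyl sulfur. For the measured compounds named here, with no measured step of this kind available, the step from compound 1 to compound 3 is expected to be modest, a 1.4-fold higher number from compound 1 to compound 3 (0.15 log units; within the scatter), possibly within the scatter and if anything toward a higher number. Compound 3 is therefore estimated at 12000 nM, with a range of 4000 nM to 40000 nM.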

Compound 3, inhibition constant: 9200 nM
Beside the measured number, compound 3's estimate is 1.3-fold (0.12 log units) above it; low and high end bracket the measured number.
By their numbers in this assay, from the lowest: compounds 1 and 3 (each within the scatter of the next); then compound 2.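

In this assay, among the compounds shown here, 4-methoxyphenyl in place of 2,4,6-trimethylphenyl on a sulfonyl sulfur gives a 1.1-fold higher number from compound 1 to compound 3 (0.03 log units; within the scatter) as the first single-change step, so compound 1 and compound 3 cannot be told apart. At this position, then, the number holds across this change of substituents on the phenyl ring, including the exchange of 9 carbon heavy atoms for 7 carbon atoms and 1 oxygen. Nothing available explains why these two groups read alike.

Still open, on these data alone, is whether an unsubstituted phenyl, a pyridine ring or a small alkyl group such as methyl on the sulfonyl sulfur would keep the number in this range. As far as these compounds go, it is equally open whether a carboxylic acid or an amine on the phenyl ring would shift it beyond the scatter.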